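This account rests on a few compounds, and the source may have more. Where it says the series, first, only, none or still open, it means among the compounds named here.

Among the compounds with values here, in a functional assay on MCF7 cells (Homo sapiens) for cytotoxicity, read by sulforhodamine B assay, with a stated time of 48 h (on this read-out lower numbers stand for stronger inhibition and higher numbers for weaker inhibition), compound 2 (`C=CCOc1ccc(C)cc1C(=O)c1cccnc1`) gives 84000 nM, the only true number available so far. Compound 1 (`C=CCOc1ccc(F)cc1C(=O)c1cccnc1`) is reported only as a limit, > 100000 nM. Within the data shown here, the one measured step, an at least 1.1-fold lower number from compound 1 to compound 2 (0.07 log units; that floor lies within the scatter), replaces fluoro with methyl on the same aromatic carbon that changes next. It rests on (the limit of > 100000 nM in this assay, at which 1 of the 2 values shown sits), so only its floor is known, and that floor lies within the scatter.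

Compound 3 (`C=CCOc1ccc(Cl)cc1C(=O)c1cccnc1`) has chloro in place of methyl on an aromatic carbon, para to an allyloxy group: chloro in place of methyl on an aromatic carbon. Among the measured compounds shown here, the only measured step at this carbon gives no size beyond the scatter, and the data hold no other step to draw on. No clear change is therefore expected in this assay, in either direction. The expected step, a 1.1-fold higher number from compound 2 to compound 3 (0.03 log units; within the scatter), is estimated to stay within the scatter. A result reported only as a limit, as for compound 1, remains a real possibility. For compound 3 the estimated value is 90000 nM, with an expected range from 40000 nM to 180000 nM.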

Compound 3, half-maximal inhibitory concentration: 54000 nM
The estimate for compound 3 lay 1.7-fold (0.22 log units) above the measured number, within the range that was stated.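

In this assay, going from methyl to chloro on this carbon, para to an allyloxy group, gives the position its first step with a real size rather than only a floor: a 1.6-fold lower number from compound 2 to compound 3 (0.19 log units; within the scatter). With fluoro, methyl and chloro now compared here, no step at this carbon has been shown to leave the scatter, and compound 2 and compound 3 cannot be placed in any order, so the exchange among these three small groups has not been seen to matter in this assay. Chloro in place of fluoro gives an at least 1.8-fold lower number from compound 1 to compound 3 (0.26 log units; that floor lies within the scatter), and the true size of that step stays unknown, as compound 1 is reported only as a limit: the limit of > 100000 nM in this assay, at which 1 of the 3 values shown sits.

The compounds shown leave open whether a different kind of group at this carbon, such as an amine, a carboxylic acid or a longer chain, would carry the number beyond the scatter. They also leave open whether any change away from this carbon, for instance an ethoxy group or a longer chain in place of the allyloxy group, would do so.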